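Ring Size of the Sulfone Substituent on the Pyrazole Nitrogen

The source may hold more compounds than are shown below. What is called first, only, known or untested is meant among the compounds shown, and "the series" means these compounds.

Measured compounds:
- compound 1, `Cc1cc(NC(=O)Cn2nnc(-c3ccccc3)n2)n(C2CCC(F)(F)CC2)n1`: 84 nM
- compound 2, `Cc1cc(NC(=O)Cn2nnc(-c3ccccc3)n2)n(C2CCS(=O)(=O)C2)n1`: 1030 nM

For the measured compounds named here, in an assay on HEK293 cells for activation of Kir3.1/Kir3.2 (Homo sapiens), read by thallium flux (a higher number here means that more compound is needed for the effect, a lower number that less compound is needed), compound 2 gives the highest of the two numbers; its nearest neighbour is compound 1, and the step of a 12-fold higher number from compound 1 to compound 2 (1.09 log units; beyond the scatter) is the only measured step here, a large one that followed the exchange of the 4,4-difluorocyclohexyl group for the 1,1-dioxothiolan-3-yl group on the aromatic nitrogen. Compound 3, `Cc1cc(NC(=O)Cn2nnc(-c3ccccc3)n2)n(C2CCS(=O)(=O)CC2)n1`, differs from compound 2 by 1,1-dioxothian-4-yl in place of 1,1-dioxothiolan-3-yl on an aromatic nitrogen, that is a six-membered sulfone ring in place of a five-membered one. Going by the values given here, no measured step isolates this ring expansion, so the expectation rests on the two values alone: compound 1 carries a six-membered ring and gives the lower number, while the sulfone remains. A moderate move toward lower numbers is therefore expected, a 2.1-fold lower number from compound 2 to compound 3 (0.31 log units; beyond the scatter), with wide uncertainty. Compound 3 is estimated at 500 nM in this assay, within 150 nM to 1600 nM.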

Compound 3, half-maximal effective concentration: > 10000 nM
Compound 3: a limit, no number; the forecaster's own chance of this, stated with the estimate: 5%; at least 20-fold (1.30 log units) between middle value and limit.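

Compound 3 gives only a limit in this assay, not a number: the limit of > 10000 nM in this assay, at which 1 of the 3 values shown sits.

Enlarging the sulfone ring by one atom at this place on the aromatic nitrogen is no minor change, since it brings an at least 9.7-fold higher number from compound 2 to compound 3 (0.98 log units; beyond the scatter). Between the two six-membered rings the change is an at least 110-fold higher number from compound 1 to compound 3 (2.07 log units; beyond the scatter), so a six-membered ring here does not by itself give a low number, and what the ring carries counts as well.

As far as these compounds go, how far compound 3 truly lies from compound 2 stays open, as does whether ring size or the place of the sulfone within the ring matters more. Also open, from the compounds shown here alone, is how a plain cyclohexyl group, or an oxan-4-yl ring with a single ring oxygen instead of the sulfone, would read in this assay.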